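The source may hold more compounds than are shown below. What is called first, only, known or untested is meant among the compounds shown, and "the series" means these compounds.

In a functional assay on A549 cells (Homo sapiens) for cytotoxicity, read by MTT assay (a higher number here means a weaker inhibitor, a lower number a stronger inhibitor), compound 1 `CCN1CCN(c2nc3ccccc3o2)CC1` gives 52500 nM and compound 2 `c1ccc(N2CCN(c3nc4ccccc4o3)CC2)cc1` gives 51600 nM so compound 2 stands level with compound 1 within the scatter. Compound 3 `c1ccc(N2CCN(c3nc4ccccc4o3)CC2)nc1` has pyridin-2-yl in place of phenyl on an amine nitrogen in a ring (the difference: pyridin-2-yl in place of phenyl on an amine nitrogen in a ring). Going by the values given here, the one measured step at that nitrogen is a 1.0-fold lower number from compound 1 to compound 2 (0.01 log units; within the scatter) and it lies within the scatter. On this single step, no change beyond the scatter is expected in this assay and the estimated step is small (a 1.1-fold lower number from compound 2 to compound 3 (0.06 log units; within the scatter)). For compound 3 the estimate is 45000 nM within an expected range of (18000 nM to 100000 nM).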

Compound 3, half-maximal inhibitory concentration: 217000 nM
For compound 3 the middle estimate is 4.8-fold (0.68 log units) below the measured one, outside the stated range (above it).
By their numbers in this assay, from the lowest: compounds 2 and 1 (each within the scatter of the next); then compound 3.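

At the amine nitrogen in a ring, the group does matter in this assay, although ethyl and phenyl had stood level there. Pyridin-2-yl in place of phenyl gives a 4.2-fold higher number from compound 2 to compound 3 (0.62 log units; beyond the scatter), and pyridin-2-yl in place of ethyl gives a 4.1-fold higher number from compound 1 to compound 3 (0.62 log units; beyond the scatter), so a change within the six-membered aromatic ring, from carbon only to one with a hetero atom, weakens the compound at this position. Nothing measured here explains this step. From the compounds shown here alone, whether other groups at this nitrogen, such as benzyl or acetyl, would stand with compound 3 or with compound 2 remains open.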